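A few compounds are considered here, and "the series" means these few. Any claim that something is new, unique, unknown or untested is made for them only; others in the source may bear on it.

Of the compounds shown here, three sharing one core have been tested in a functional assay on HT-29 cells (Homo sapiens) for antiproliferative activity, read by MTT assay, with a stated time of 48 h; a lower number here means a stronger inhibitor of growth, a higher number a weaker inhibitor of growth. Compound 1 `CCOC(=O)N1N=C(c2ccc(OC)cc2)CC1c1cc(OC)c(OC)c(OC)c1` gives 6730 nM and compound 2 `CCCOC(=O)N1N=C(c2ccc(OC)cc2)CC1c1cc(OC)c(OC)c(OC)c1` gives 12700 nM, two numbers that lie within the scatter of each other. Compound 3 `COc1ccc(C2=NN(C(=O)OCc3ccccc3)C(c3cc(OC)c(OC)c(OC)c3)C2)cc1` reports only a limit, > 10000 nM.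

Compound 4 `CCCOC(=O)N1N=C(c2cccc(O)c2)CC1c1cc(OC)c(OC)c(OC)c1` keeps the propoxycarbonyl group of compound 2 but carries 3-hydroxyphenyl in place of 4-methoxyphenyl on a carbon with a double bond to nitrogen. The measured steps all alter the chain on the oxygen next to the carbonyl group. The first is a 1.9-fold higher number from compound 1 to compound 2 (0.28 log units; within the scatter), and the second is an at least 1.4-fold higher number from compound 1 to compound 3 (0.17 log units; that floor lies within the scatter). Neither touches the carbon that changes here, so they offer no direct guide to size or direction, and the small size of these steps is only weak support for a small step here. The expected change in this assay is therefore none beyond the scatter, and the estimated step is a 1.3-fold lower number from compound 2 to compound 4 (0.10 log units; within the scatter). Compound 4 is estimated at 10000 nM, with an expected range from 3000 nM to 30000 nM.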

Compound 4, concentration for 50% growth inhibition: 15200 nM
Beside the measured number, compound 4's estimate is 1.5-fold (0.18 log units) below it; measured number inside the range.
By their numbers in this assay, from the lowest: compounds 1, 2 and 4 (each within the scatter of the next, the first and the last beyond it).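

This is the first change shown on the carbon with a double bond to nitrogen, rather than on the chain of the carbonyl side, and in this assay it gives a 1.2-fold higher number from compound 2 to compound 4 (0.08 log units; within the scatter). Replacing 4-methoxyphenyl with 3-hydroxyphenyl brings in a hydrogen-bond donor and removes one heavy atom, yet the number stays within the scatter, so this particular swap neither gains nor loses readable growth inhibition. Nothing measured here offers a cause for this result.

The swap alters both the oxygen-bearing group and where it sits on the phenyl ring, so the two changes cannot be told apart in these compounds. From the compounds shown here alone, it remains open how 4-hydroxyphenyl, 3-methoxyphenyl or an aminophenyl group would read at this carbon, and whether any of them would move the number beyond the scatter.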